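The compounds below may be only part of what the source reports. "The series", "measured", "known", "first", "only" and "open" are said of these compounds alone.

Compound 1 `CCc1ccc(/C(=C\CC(N)C(=O)O)c2ccc(F)cc2F)cc1` gives in a functional assay for inhibition of sodium- and chloride-dependent glycine transporter 1 (Rattus norvegicus), with a stated time of 30 min, in the presence of a further agent that is not named here (a lower number here means a stronger inhibitor, a higher number a weaker inhibitor), a limit, > 10000 nM.
Compound 2 `COc1ccc(/C(=C/CC(N)C(=O)O)c2ccc(C(C)C)cc2)cc1` likewise gives only a limit, > 10000 nM.
Compound 3 `CC(C)c1ccc(/C(=C\CC(N)C(=O)O)c2ccccc2)cc1` gives 8340 nM.

Within the data shown here, compound 3 therefore stands as the only measured number among the three; the other two rest at the limit (the limit of > 10000 nM in this assay, at which 2 of the 3 values shown sit). Among the measured compounds shown here, the one step between neighbours that differ in a single place, an at least 1.1-fold lower number from compound 2 to compound 3 (0.07 log units; that floor lies within the scatter), concerns a group on the other ring and has a floor that lies within the scatter, so it says little about the change now in view. Compound 4 `CC(C)c1ccc(/C(=C\CC(N)C(=O)O)c2ccccc2F)cc1` differs from compound 3 by fluoro in place of hydrogen on an aromatic carbon. For the measured compounds named here, no measured step tests this change directly. The expected step is a 1.1-fold higher number from compound 3 to compound 4 (0.03 log units; within the scatter), nothing beyond the scatter. For compound 4 the estimate is 9000 nM, between 3500 nM and 25000 nM.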

Compound 4, half-maximal inhibitory concentration: 8020 nM
Compound 4: the middle estimate sits 1.1-fold (0.05 log units) above what was measured; measured number inside the range.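

Phenyl to 2-fluorophenyl is the first change at this position that can be read directly, and in this assay it stays within the scatter: a 1.0-fold lower number from compound 3 to compound 4 (0.02 log units; within the scatter). A single fluoro here therefore leaves the number in place, at least on this shared core. The other new step, an at least 1.2-fold lower number from compound 2 to compound 4 (0.09 log units; that floor lies within the scatter), starts from a limit, so it gives only a floor within the scatter and cannot be sized.

As far as these compounds go, whether an amine or a carboxylic acid at this position would move the number beyond the scatter remains open.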